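The source may hold more compounds than are shown below. What is called first, only, known or untested is meant among the compounds shown, and "the series" means these compounds.

Measured compounds in a functional assay on Caco-2 cells (Homo sapiens) for inhibition, read by MTT assay, with a stated time of 48 h; a lower number here means a stronger inhibitor, a higher number a weaker inhibitor:
- compound 1 `COc1ccccc1-c1csc(N/N=C/c2ccc(F)c(F)c2)n1`: 25200 nM
- compound 2 `Fc1ccc(/C=N/Nc2nc(-c3ccccc3)cs2)cc1F`: 20900 nM
- compound 3 `COc1cc(/C=N/Nc2nc(-c3ccccc3)cs2)cc(Br)c1OC`: 64200 nM

Compound 3 gives the highest of the three numbers; against compound 1 it stands beyond the scatter, and against compound 2 likewise. The difference between the cores of compound 3 and compound 2 is not broken down here.

Compound 4 `COc1ccccc1-c1csc(N/N=C/c2cc(Br)c(OC)c(OC)c2)n1` has not yet been measured in this assay. It is derived from compound 3 by methoxy in place of hydrogen on an aromatic carbon. The same change occurs once more among the measured pair, where compound 1 is derived from compound 2 by methoxy in place of hydrogen on an aromatic carbon; the two place descriptions agree word for word, so this is the same change. That earlier step is a 1.2-fold higher number from compound 2 to compound 1 (0.08 log units; within the scatter).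

Within the data shown here, for compound 4 the step is expected to be a 1.1-fold higher number from compound 3 to compound 4 (0.05 log units; within the scatter), resting on the single precedent a 1.2-fold higher number from compound 2 to compound 1 (0.08 log units; within the scatter) and on the value of compound 3, 64200 nM. Among the measured compounds shown here, with only one precedent, a wider band is kept. Compound 4 is thus estimated at 72000 nM, within 35000 nM to 150000 nM.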

Compound 4, half-maximal inhibitory concentration: > 100000 nM
Compound 4 ended at the assay's limit (the forecaster's own chance of this, stated with the estimate: 15%); at least 1.3-fold (0.14 log units) between middle value and limit.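

In this assay, compound 4 gives > 100000 nM, which is a limit of the assay and not a number. Going by these compounds, the change from phenyl to 2-methoxyphenyl gives an at least 1.5-fold higher number from compound 3 to compound 4 (0.19 log units; that floor lies within the scatter), so on this core it shows no gain in inhibition, but the true size of the step remains unknown and may be larger than this floor. The result therefore does not establish that the change carries across the two cores with the same size, nor that its size differs between them: the same change on two cores in this assay, a 1.2-fold higher number (0.08 log units; within the scatter) from compound 2 to compound 1 and an at least 1.5-fold higher number (0.19 log units; that floor lies within the scatter) from compound 3 to compound 4; the limit leaves it open whether they differ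

The compounds shown leave open whether the same change behaves alike on any further core in the series, since this comparison rests on just two pairs. They also leave open whether a different group at the same place, such as an amine, a carboxylic acid or a longer chain, would move the number beyond the scatter in either direction.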